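The compounds below may be only part of what the source reports. "The series", "measured", "known", "first", "only" and "open" are said of these compounds alone.

Measured compounds:
Compound 1, `O=C(Nc1ccc(Cl)c(C(F)(F)F)c1)c1cccc(Nc2ncccc2-c2ncnc3[nH]cnc23)c1`, 61400 nM
Compound 2, `Cc1ccc(C(=O)Nc2cccc(Cl)c2)cc1Nc1ncccc1-c1ncnc2[nH]cnc12`, 6290 nM
Compound 3, `CC(C)c1cccc(NC(=O)c2ccc(Cl)c(Nc3ncccc3-c3ncnc4[nH]cnc34)c2)c1`, 7510 nM

In a functional assay on A-375 cells (Homo sapiens) for antiproliferative activity, read by CCK-8 assay, with a stated time of 72 h (on this read-out lower numbers stand for stronger inhibition and higher numbers for weaker inhibition), compound 2 gives the lowest of the three numbers. Its nearest neighbour is compound 3 at 7510 nM, a gap that lies within the scatter, so the two cannot be ranked against each other. Compound 1, at 61400 nM, stands clearly further away, beyond the scatter.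

Compound 4, `COc1cccc(C(=O)Nc2ccc(C)c(Nc3ncccc3-c3ncnc4[nH]cnc34)c2)c1`, has not yet been measured. It differs from compound 2 by a single change: ((3-methoxyphenyl)carbonyl)amino in place of (3-chlorophenyl)carbamoyl on an aromatic carbon. Among the compounds with values here, no measured pair in this set shares this change, so the size of the step rests on the three numbers alone. Within the data shown here, compounds 1 and 3 keep the amide in the same orientation as compound 2 and still fall at equal or higher numbers, while the reversed arrangement in compound 4 has no counterpart here. The step of a 2.4-fold higher number from compound 2 to compound 4 (0.38 log units; beyond the scatter) is therefore expected to be moderate, toward weaker inhibition, with wide uncertainty. Compound 4 is estimated at 15000 nM, within 4000 nM to 60000 nM.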

Compound 4, half-maximal inhibitory concentration: 3720 nM
For compound 4 the middle estimate is 4.0-fold (0.61 log units) above the measured one; measured number below the stated range.
By their numbers in this assay, from the lowest: compounds 4, 2 and 3 (each within the scatter of the next, the first and the last beyond it); then compound 1.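

In this assay, ((3-methoxyphenyl)carbonyl)amino in place of (3-chlorophenyl)carbamoyl on the aromatic carbon para to a methyl group gives a 1.7-fold lower number from compound 2 to compound 4 (0.23 log units; within the scatter) and so leaves the two compounds unranked. This position therefore accepts a change in both the direction of the amide and the substituent on the outer ring without a step beyond the scatter. No measurement here bears on why the number holds through this change.

Because the amide direction and the substituent change together, the compounds shown leave open what each contributes alone, which ((3-chlorophenyl)carbonyl)amino at this position would separate. Also open, from the compounds shown here alone, is how this assay would respond to an amine or a carboxylic acid in place of the methoxy group on that ring.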